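Demethoxylation across two chromone-type cores

The source may report more compounds than this note shows. Statements on the series, on what has been measured and on what is new or still open speak of the compounds shown alone.

In a functional assay on SW480 cells (Homo sapiens) for antiproliferative activity, read by MTT assay, with a stated time of 72 h (a lower number here means a stronger inhibitor, a higher number a weaker inhibitor), compound 1 `COc1ccc2oc(CSC(=S)N3CCOCC3)cc(=O)c2c1` gives 3100 nM, and compound 3 `O=c1cc(CSC(=S)N2CCOCC2)oc2ccccc12` gives 24400 nM. The change between them, (hydrogen in place of methoxy on an aromatic carbon), produced a 7.9-fold higher number from compound 1 to compound 3 (0.90 log units; beyond the scatter). Within the data shown here, compound 2 `COc1ccc2occ(CSC(=S)N3CCCCC3)c(=O)c2c1` gives 6700 nM in this assay; the difference between the core of compound 2 and the core of compound 1 is not broken down here, and no step is given for that pair, so their two values stand on their own. Compound 4 `O=c1c(CSC(=S)N2CCCCC2)coc2ccccc12` is not yet measured in this assay. It differs from compound 2 by hydrogen in place of methoxy on an aromatic carbon, the same change that was made from compound 1 to compound 3, with the place described in the same words. The methoxy-to-hydrogen step has so far been seen once, and only on one core, so the second occurrence carries uncertainty. The expected step from compound 2 to compound 4 is a 6.0-fold higher number from compound 2 to compound 4 (0.78 log units; beyond the scatter), resting on the earlier 7.9-fold higher number from compound 1 to compound 3 (0.90 log units; beyond the scatter) and on the starting value of compound 2 at 6700 nM. Compound 4 is estimated at 40000 nM in this assay, with a range expected from 15000 nM to 110000 nM.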

Compound 4, half-maximal inhibitory concentration: 1200 nM
Compound 4: middle estimate off by 33-fold (1.52 log units), on the high side; measured number outside the range, below it.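

In this assay, hydrogen in place of methoxy on an aromatic carbon gives a 5.6-fold lower number from compound 2 to compound 4 (0.75 log units; beyond the scatter), so the loss of potency seen on the first core does not recur on the second, and the change reverses direction. The two occurrences cannot be treated as one transferable step in this series: the same change on two cores in this assay, a 7.9-fold higher number (0.90 log units; beyond the scatter) from compound 1 to compound 3 and a 5.6-fold lower number (0.75 log units; beyond the scatter) from compound 2 to compound 4, 44-fold (1.64 log units) apart, beyond the scatter of two such steps. This shows that the effect of removing methoxy depends on its molecular context here, but it does not show which structural difference sets the direction, as the two pairs differ from each other in more than one place and each direction rests on a single pair.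

Open, on these data alone, is whether the direction of the step follows the core or the side chain, which a pair combining the side chain of one series with the core of the other could separate. Also open, as far as these compounds go, is how a group such as hydroxy or chlorine would compare with methoxy and hydrogen on that same aromatic carbon on each core.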